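Swapping pyrazine for pyrrole on a shared imidazoline scaffold

The source may hold more compounds than are shown below. What is called first, only, known or untested is meant among the compounds shown, and "the series" means these compounds.

Compound 1, `Cc1ccnc(-c2ccccc2OCC2=NCCN2)c1`: < 100000 nM in a functional assay for activation of Alpha-1D adrenergic receptor (Homo sapiens), read by calcium flux; a higher number here means that more compound is needed for the effect, a lower number that less compound is needed
Compound 2, `c1ccc(-c2cnccn2)c(OCC2=NCCN2)c1`: < 100000 nM in this assay

Compound 1 gives < 100000 nM in this assay, which is a limit of the assay rather than a number. Compound 2 gives < 100000 nM in this assay, again only a limit. So compound 2 stands nowhere definite on the numbers shown: both values sit at the limit of < 100000 nM in this assay, at which 2 of the 2 values shown sit, and no step between measured compounds can be read from them.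

Compound 3, `c1c[nH]c(-c2ccccc2OCC2=NCCN2)c1`, has not yet been measured. It differs from compound 2 by 1H-pyrrol-2-yl in place of pyrazin-2-yl on an aromatic carbon. Among the measured compounds shown here, no measured step tells how large a change of this kind is in this assay, so the size and direction of the step to compound 3 is open; a step beyond the scatter in either direction is possible, and a further limit is also possible.

Compound 3 is therefore expected to give roughly 5000 nM in this assay, somewhere between 300 nM and 80000 nM. That estimate means an expected step that the limit leaves unreadable from compound 2 to compound 3, held loosely.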

Compound 3, half-maximal effective concentration: 6.31 nM
For compound 3 the middle estimate is 790-fold (2.90 log units) above the measured one, and the stated range ends above it.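

No step from compound 2 to compound 3 can be read, as the value of compound 2 is a limit of the assay and not a number: the limit of < 100000 nM in this assay, at which 2 of the 3 values shown sit.

The compounds shown leave open how large a change 1H-pyrrol-2-yl in place of pyrazin-2-yl makes in this assay, and in which direction.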